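The source may hold more compounds than are shown below. What is called first, only, known or untested is meant among the compounds shown, and "the series" means these compounds.

Measured compounds:
compound 1, `CC(O)(CSc1cccc(C(F)(F)F)c1)C(=O)Nc1cccc(S(F)(F)(F)(F)F)c1`, 20200 nM
compound 2, `CC(O)(CSc1ccccc1C(F)(F)F)C(=O)Nc1cccc(S(F)(F)(F)(F)F)c1`, 21000 nM
compound 3, `CC(O)(CS(=O)(=O)c1cccc(C(F)(F)F)c1)C(=O)Nc1ccc(S(F)(F)(F)(F)F)cc1`, 32000 nM

In a functional assay on VCaP cells (Homo sapiens) for antiproliferative activity, read by propidium iodide staining, with a stated time of 96 h (a higher number here means a weaker inhibitor, a lower number a stronger inhibitor), compound 1 gives 20200 nM, and compound 2 gives 21000 nM. The change between them is 2-(trifluoromethyl)phenyl in place of 3-(trifluoromethyl)phenyl on a sulfur, and it made a step of a 1.0-fold higher number from compound 1 to compound 2 (0.02 log units; within the scatter). Compound 3 gives 32000 nM in this assay; how its core differs from the core of compound 1 is not broken down here. Compound 4, `CC(O)(CS(=O)(=O)c1ccccc1C(F)(F)F)C(=O)Nc1ccc(S(F)(F)(F)(F)F)cc1`, is not yet measured. It differs from compound 3 by 2-(trifluoromethyl)phenyl in place of 3-(trifluoromethyl)phenyl on a sulfonyl sulfur, the same kind of change as from compound 1 to compound 2, though here the place is a sulfonyl sulfur rather than a sulfur. Because the earlier step was a 1.0-fold higher number from compound 1 to compound 2 (0.02 log units; within the scatter), compound 4 is expected to give about 32000 nM in this assay, a step of no change at the digits printed from compound 3 to compound 4 (within the scatter), between 16000 nM and 64000 nM.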

Compound 4, half-maximal inhibitory concentration: 23800 nM
The estimate for compound 4 lay 1.3-fold (0.13 log units) above the measured number; the range from low to high includes it.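

Putting 2-(trifluoromethyl)phenyl in place of 3-(trifluoromethyl)phenyl on a sulfonyl sulfur gave a 1.3-fold lower number from compound 3 to compound 4 (0.13 log units; within the scatter) in this assay, and set beside the step on the other core, the change carried over with no difference that can be told apart: the same change on two cores in this assay, a 1.0-fold higher number (0.02 log units; within the scatter) from compound 1 to compound 2 and a 1.3-fold lower number (0.13 log units; within the scatter) from compound 3 to compound 4, 1.4-fold (0.15 log units) apart, within the scatter of two such steps. On both cores shown, the swap left the number within the scatter. This does not show that the change would stay as small on other cores, since it rests on two pairs, neither with a step beyond the scatter.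

The compounds shown leave open how a phenyl bearing a nitrile or a chlorine in place of trifluoromethyl would behave on the sulfur. They also leave open what an amine in place of the hydroxyl group would do.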